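The source may report more compounds than this note shows. Statements on the series, on what has been measured and on what is new or still open speak of the compounds shown alone.

Measured so far in a functional assay on CHO cells with adenosine receptor A1 (Homo sapiens) as the target, read by cAMP accumulation and immunoassay, with a stated time of 6 min, tested at 0.01 uM; a lower number here means a stronger effect, a higher number a weaker effect of the compound at the concentration tested:

Compound 1 `CC(C)N1CCN(Cc2csc(N)c2C(=O)c2ccc(Cl)cc2)CC1`: -1%
Compound 2 `Nc1scc(CN2CCN(c3ccncc3)CC2)c1C(=O)c1ccc(Cl)cc1`: -4%

Both numbers sit close to zero and within the scatter of each other, so compound 2 stands level with compound 1 on the numbers shown; neither compound shows an effect at the concentration tested. Compound 3 `Nc1scc(CN2CCN(c3ccccc3F)CC2)c1C(=O)c1ccc(Cl)cc1` is the next compound to be measured. It differs from compound 2 in one place: 2-fluorophenyl in place of pyridin-4-yl on an amine nitrogen in a ring. Among the compounds with values here, the one measured step that bears on this change is the one at the same ring nitrogen, a number 3 percentage points lower from compound 1 to compound 2 (within the scatter), which stayed within the scatter. On that basis the exchange of the group on the ring nitrogen is expected to leave the read-out where it is, and the step of a number 1 percentage points higher from compound 2 to compound 3 (within the scatter) is estimated to stay within the scatter. Compound 3 is therefore expected to give about -3% in this assay, with a range from -13% to 8%.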

Compound 3, a percentage reported as activity, at one concentration (the size of the read-out at that concentration, not a potency): 2.1%
The estimate for compound 3 lay 5.1 percentage points below the measured number, within the range that was stated.
By their numbers in this assay, from the lowest: compounds 2, 1 and 3 (each within the scatter of the next).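

In this assay, the ring nitrogen now carries a third type of group without the read-out separating: 2-fluorophenyl in place of pyridin-4-yl gives a number 6.1 percentage points higher from compound 2 to compound 3 (within the scatter), and 2-fluorophenyl in place of isopropyl gives a number 3.1 percentage points higher from compound 1 to compound 3 (within the scatter). At this position, exchanging an aromatic ring with a hetero atom for a fluorinated ring of carbon only therefore leaves compound 3 level with compound 2, as the earlier exchange of isopropyl for pyridin-4-yl left compound 2 level with compound 1. No evidence is available that would explain this flat result.

On these data alone, whether a carboxylic acid or a longer alkyl chain on the same ring nitrogen would move the read-out remains open. Also open, as far as these compounds go, is whether these three compounds would separate at any other concentration, since one concentration gives no potency.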